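A few compounds are considered here, and "the series" means these few. Any claim that something is new, unique, unknown or untested is made for them only; others in the source may bear on it.

In a functional assay on Ishikawa cells (Homo sapiens) for antiproliferative activity, read by MTT assay, with a stated time of 24 h (a lower number here means that less compound is needed, a higher number that more compound is needed for the effect), compound 1 (`CSc1ccc(/C(=N\O)c2cccc3ccccc23)cc1`) gives only a limit (> 50000 nM). Compound 2 (`CCN(CC)C(=O)CO/N=C(\c1ccc(SC)cc1)c1cccc2ccccc12`) also gives only a limit (> 50000 nM). Compound 3 (`CCCCC(CC)CNCCCO/N=C(\c1ccc(OC)cc1)c1cccc2ccccc12`) gives a limit as well (> 50000 nM). Compound 2 thus stands at the limit of > 50000 nM in this assay, at which 3 of the 3 values shown sit, and has no number of its own. Among the compounds with values here, the only measured step is a step that the two limits leave unreadable from compound 1 to compound 2 and it offers no size to carry forward.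

The change to compound 4 (`CSc1ccc(/C(=N\OCCCCN2CCCC2)c2cccc3ccccc23)cc1`) is 3-(pyrrolidin-1-yl)propyl in place of diethylcarbamoyl on a saturated chain carbon bound to an oxygen on an unsaturated carbon and the side chain thereby becomes 4-(pyrrolidin-1-yl)butoxy in place of (diethylcarbamoyl)methoxy. Within the data shown here, no measured step bears on this exchange, so any expectation in this assay is tentative. At most a modest move towards less compound being needed is expected, and another result at the limit remains quite possible. The expected change is an at least 1.6-fold lower number from compound 2 to compound 4 (0.22 log units; that floor lies within the scatter) and its size is uncertain. For compound 4 the estimate is 30000 nM with an expected range from 8000 nM to 50000 nM in this assay.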

Compound 4, half-maximal effective concentration: > 50000 nM
Compound 4 gave a limit, no number (the forecaster's own chance of this, stated with the estimate: 55%); at least 1.6-fold (0.22 log units) between middle value and limit.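

Compound 4 gives only a limit in this assay as well, so the steps from compound 1 and compound 2 to compound 4 cannot be read. The compounds shown leave open whether any side chain on the shared core gives a readable number and how far such numbers would differ: the limit of > 50000 nM in this assay, at which 4 of the 4 values shown sit.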